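The compounds below may be only part of what the source reports. "The series", "measured", "known", "first", "only" and "open" are said of these compounds alone.

In a functional assay, read by spectrophotometry, with a stated time of 30 min (on this read-out higher numbers stand for weaker inhibition and lower numbers for stronger inhibition), compound 1 `O=C(/C=C/c1ccccc1)NCCC1CCN(Cc2ccccc2)CC1` reaches only a limit of the assay, > 200000 nM. Compound 2 `CC(C)(C)c1cc(CCC(=O)NC2CCN(Cc3ccccc3)CC2)cc(C(C)(C)C)c1O` gives 80300 nM and compound 3 `Cc1ccccc1CN1CCC(CCNC(=O)/C=C/c2cc(C(C)(C)C)c(O)c(C(C)(C)C)c2)CC1` gives 65300 nM, so compound 3 lies within the scatter of compound 2. Compound 4 `CC(C)(C)c1cc(/C=C/C(=O)NCCC2CCN(Cc3cccc(F)c3)CC2)cc(C(C)(C)C)c1O` has not yet been measured. It carries 3-fluorophenyl in place of the 2-methylphenyl of compound 3, on a saturated chain carbon bound to an amine nitrogen in a ring (3-fluorophenyl in place of 2-methylphenyl on a saturated chain carbon bound to an amine nitrogen in a ring). Among the compounds with values here, no pair of measured compounds isolates this change, so the expected step in this assay is small, a 1.1-fold lower number from compound 3 to compound 4 (0.04 log units; within the scatter), and not beyond the scatter. For compound 4 the estimated value is 60000 nM, with an expected range of 22000 nM to 160000 nM.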

Compound 4, half-maximal inhibitory concentration: 55200 nM
The estimate for compound 4 lay 1.1-fold (0.04 log units) above the measured number, and the stated range covers the measured number.
By their numbers in this assay, from the lowest: compounds 4, 3 and 2 (each within the scatter of the next). At a limit, above all of these: compound 1.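

In this assay, within the data shown here, the change from 2-methylbenzyl to 3-fluorobenzyl gives the only single-place comparison available, a 1.2-fold lower number from compound 3 to compound 4 (0.07 log units; within the scatter). On a saturated chain carbon bound to an amine nitrogen in a ring, 3-fluorophenyl in place of 2-methylphenyl therefore leaves the number within the scatter. Nothing measured here gives a cause for this step. The compounds shown leave open whether a methoxyphenyl, a pyridine ring or a cyclohexyl group at this place would move the number beyond the scatter.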